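Fluoro in Place of Hydrogen: What Permeability to Expect

A few compounds are considered here, and "the series" means these few. Any claim that something is new, unique, unknown or untested is made for them only; others in the source may bear on it.

Measured compounds:
- compound 1, `CC(C)c1nnc2n1C[C@H](C)N(C(=O)c1cccc(C(F)(F)c3n[nH]c(=O)c4ccccc34)c1)C2`, gives 2 10^-6 cm/s
- compound 2, `C[C@@H]1Cn2c(nnc2C(F)(F)F)CN1C(=O)c1cccc(Cc2n[nH]c(=O)c3ccccc23)c1`, gives 1.5 10^-6 cm/s
- compound 3, `O=C(c1cccc(Cc2n[nH]c(=O)c3ccccc23)c1)N1CCn2c(nnc2C(F)(F)F)C1`, gives 1.3 10^-6 cm/s

These three values come from an ADME assay on Caco-2 cells (Homo sapiens) for permeability, read by LC-MS, with a stated time of 2 h, at pH 7.4, tested at 10 uM; a lower number here means that the compound crosses the layer more slowly, a higher number that the compound crosses the layer faster. Compound 1 has the highest of the three numbers, but its nearest neighbour, compound 2, lies within the usual scatter of it, and so does compound 3; the three compounds therefore cannot be told apart on this assay.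

The unmeasured compound 4, `C[C@H]1Cn2c(nnc2C(C)(C)F)CN1C(=O)c1cccc(C(F)(F)c2n[nH]c(=O)c3ccccc23)c1`, differs from compound 1 in one place: fluoro in place of hydrogen on a saturated chain carbon bound to an aromatic carbon and two saturated chain carbons.

Among the measured compounds shown here, the only single-point step among the measured compounds is a 1.2-fold lower number from compound 2 to compound 3 (0.06 log units; within the scatter), a change of methyl to hydrogen on a saturated ring carbon, which lies within the scatter. It concerns a different part of the molecule and a different kind of exchange, so it does not bear directly on the fluoro-for-hydrogen change. For the measured compounds named here, nothing among the measured compounds shows what a fluoro entering at this place does in this assay. In the absence of any such evidence, no step beyond the scatter is expected from compound 1 to compound 4 in this assay, that is no change at the digits printed from compound 1 to compound 4 (within the scatter). Compound 4 is therefore estimated to give 2 10^-6 cm/s, with a range from 1 10^-6 cm/s to 4 10^-6 cm/s.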

Compound 4, apparent permeability: 5.9 10^-6 cm/s
Estimate against measurement, compound 4: 3.0-fold (0.47 log units) below; measured number above the stated range.
By their numbers in this assay, from the lowest: compounds 3, 2 and 1 (each within the scatter of the next); then compound 4.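

The isopropyl position of compound 1 turns out not to be a silent place in this assay: replacing isopropyl with 1-fluoro-1-methylethyl gives a 3.0-fold higher number from compound 1 to compound 4 (0.47 log units; beyond the scatter) and so moves the number beyond the scatter. The one earlier step, a 1.2-fold lower number from compound 2 to compound 3 (0.06 log units; within the scatter) at another place and with another exchange, stayed within the scatter, so the earlier compounds had shown no change of this size. Here a single fluorine atom, on a saturated chain carbon bound to an aromatic carbon and two saturated chain carbons, is the whole difference between the two structures, yet nothing shown gives a reason for the step.

This single pair cannot tell whether the step belongs to fluoro in particular or would also appear with another group on the same carbon, such as a hydroxyl, a methoxy or a nitrile. It also leaves open whether a longer chain carrying fluoro, or an amine at this carbon, would give a number closer to that of compound 1 or to that of compound 4.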